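A few compounds are considered here, and "the series" means these few. Any claim that something is new, unique, unknown or untested is made for them only; others in the source may bear on it.

Measured so far:
compound 1, `O=C(c1sc(-c2cccc(F)c2)nc1O)N1CCCOC1` — in an assay on HEK293 cells for inhibition of transient receptor potential cation channel subfamily M member 8 (Homo sapiens), read by FLIPR, with stated times of 5 min and 3 min (a higher number here means a weaker inhibitor, a lower number a stronger inhibitor), compound 1 gives > 100000 nM, which is a limit of the assay rather than a number.
compound 2, `CON(C)C(=O)c1sc(-c2cccc(F)c2)nc1O` — in this assay compound 2 gives 96 nM.

Going by the values given here, compound 2 is the only compound with a number in this assay; the other value is a limit (the limit of > 100000 nM in this assay, at which 1 of the 2 values shown sits). The step of an at least 1000-fold lower number from compound 1 to compound 2 (3.01 log units; beyond the scatter) is large. Compound 3, `O=C(c1sc(-c2cccc(F)c2)nc1O)N1CCCCCO1`, carries a group of 7 heavy atoms (5 carbon, 1 nitrogen, 1 oxygen; one seven-membered non-aromatic ring with 2 hetero atoms) in place of a group of 4 heavy atoms (2 carbon, 1 nitrogen, 1 oxygen; no ring), on a carbonyl carbon. Among the compounds with values here, that bears on the measured step only loosely, since the ring entering here differs from the one leaving in compound 1, so a weakening beyond the scatter is expected, though smaller than the measured step. The estimate for compound 3 is 1000 nM, between 100 nM and 20000 nM, an expected step of a 10-fold higher number from compound 2 to compound 3 (1.02 log units; beyond the scatter).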

Compound 3, half-maximal inhibitory concentration: 32 nM
Compound 3: middle estimate off by 31-fold (1.49 log units), on the high side, outside the stated range (below it).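

On the carbonyl carbon, a ring does not in itself abolish activity: replacing the open methoxy(methyl)amino group with the seven-membered ring gives a 3.0-fold lower number from compound 2 to compound 3 (0.48 log units; beyond the scatter). Exchanging the six-membered ring of compound 1 for this seven-membered ring gives an at least 3100-fold lower number from compound 1 to compound 3 (3.49 log units; beyond the scatter). That step starts from a limit of the assay, not a number: the limit of > 100000 nM in this assay, at which 1 of the 3 values shown sits.

The compounds shown leave open how much of this difference comes from ring size and how much from the placing of the ring oxygen. They also leave open whether an azepane, with no ring oxygen, would match compound 3.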